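A few compounds are considered here, and "the series" means these few. Any claim that something is new, unique, unknown or untested is made for them only; others in the source may bear on it.

In a functional assay on brain (Rattus norvegicus, strain Wistar) for inhibition (on this read-out lower numbers stand for stronger inhibition and higher numbers for weaker inhibition), compound 1 `Cc1[nH]c(=O)n(C2CCCCC2)c1-c1ccccc1` gives 47600 nM, compound 2 `Cc1[nH]c(=O)n(C)c1-c1ccc(OC(C)C)cc1` gives 20400 nM, and compound 3 `COc1ccc(-c2c(C)[nH]c(=O)n2C2CCCCC2)cc1` gives 20400 nM. Compound 3 thus sits level with compound 2, and both lie under compound 1. Compound 4 `Cc1[nH]c(=O)n(C2CCCCC2)c1-c1ccc(OC(C)C)cc1` has isopropyl in place of methyl on an oxygen on an aromatic ring. For the measured compounds named here, no measured step covers this exact change. The closest is a 2.3-fold lower number from compound 1 to compound 3 (0.37 log units; beyond the scatter), a modest gain from adding methoxy in place of hydrogen. Compound 2 also carries isopropoxy and reads 20400 nM, but it differs from compound 4 elsewhere. A small further drop is expected, namely a 1.4-fold lower number from compound 3 to compound 4 (0.13 log units; within the scatter), which would stay within the scatter. For compound 4 the estimate is 15000 nM, with an expected range from 6000 nM to 38000 nM.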

Compound 4, half-maximal inhibitory concentration: 13000 nM
The estimate for compound 4 lay 1.2-fold (0.06 log units) above the measured number, within the range that was stated.
By their numbers in this assay, from the lowest: compounds 4, 2 and 3 (each within the scatter of the next); then compound 1.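

In this assay, isopropyl in place of methyl on this oxygen gives a 1.6-fold lower number from compound 3 to compound 4 (0.20 log units; within the scatter) and so causes no clear shift. Cyclohexyl in place of methyl on the aromatic nitrogen likewise gives a 1.6-fold lower number from compound 2 to compound 4 (0.20 log units; within the scatter) and so no clear shift. Isopropoxy in place of hydrogen gives a 3.7-fold lower number from compound 1 to compound 4 (0.56 log units; beyond the scatter) and, like methoxy, clears the scatter.

No measurement offered here explains these steps. As far as these compounds go, whether a longer chain on this oxygen or an amine at this place would change the number remains open.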